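Aryl exchange on the shared core: expecting compound 3

A few compounds are considered here, and "the series" means these few. Any claim that something is new, unique, unknown or untested is made for them only; others in the source may bear on it.

Values so far in a physicochemical assay for lipophilicity (a lower number here means a more polar compound, a higher number a more lipophilic compound), for two compounds
- compound 1 `C[C@H]1CC[C@@H]2[C@@H](OC(=O)[C@]23CC(c2c(Cl)cccc2Cl)=NO3)[C@]2(C)C(=O)C=C[C@@]12O` at 2.67
- compound 2 `C[C@H]1CC[C@@H]2[C@@H](OC(=O)[C@]23CC(c2ccc(O)cc2)=NO3)[C@]2(C)C(=O)C=C[C@@]12O` at 0.932

Compound 2 holds the lower of the two numbers. Compound 3 `C[C@H]1CC[C@@H]2[C@@H](OC(=O)[C@]23CC(c2ccccc2[N+](=O)[O-])=NO3)[C@]2(C)C(=O)C=C[C@@]12O` has 2-nitrophenyl in place of 4-hydroxyphenyl on a carbon with a double bond to nitrogen. Going by the values given here, the one measured step at this place is large (a number 1.74 log units lower from compound 1 to compound 2 (beyond the scatter)) and ends on the same 4-hydroxyphenyl group. With that group leaving, a move upward of smaller size, beyond the scatter, is expected (a number 0.87 log units higher from compound 2 to compound 3 (beyond the scatter)). For compound 3 the estimated value is 1.8 (range 1.3 to 2.3).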

Compound 3, partition coefficient: 1.37
Estimate against measurement, compound 3: 0.43 log units above; measured number inside the range.
By their numbers in this assay, from the lowest: compound 2; then compound 3; then compound 1.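

In this assay, placing 2-nitrophenyl on the carbon with a double bond to nitrogen gives a number 0.44 log units higher from compound 2 to compound 3 (beyond the scatter), and exchanging 2,6-dichlorophenyl for it gives a number 1.30 log units lower from compound 1 to compound 3 (beyond the scatter). The three aryl groups at this place now give three separate levels, with compound 3 between compound 2 and compound 1 and closer to compound 2. No measurement at hand accounts for this order. As far as these compounds go, whether a phenyl bearing an amine or a carboxylic acid falls inside this range remains open, as does the level of an unsubstituted phenyl.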